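From compound 1 to compound 3: a step in solubility

The source may report more compounds than this note shows. Statements on the series, on what has been measured and on what is new or still open speak of the compounds shown alone.

Measured in a physicochemical assay for solubility, at pH 7.9; on this read-out higher numbers stand for higher solubility and lower numbers for lower solubility:
- Compound 1 `O=c1c(-c2ccc(Cl)cc2)cn(C2CC2)c2cc(N3CCNCC3)c(F)cc12`: > 400000 nM, a limit
- Compound 2 `COc1ccc(-c2cn(C3CC3)c3cc(N4CCNCC4)c(F)cc3c2=O)cc1`: > 400000 nM, a limit

Compound 1 stands at a limit and not at a number, > 400000 nM. The evidence so far is the limit of > 400000 nM in this assay, at which 2 of the 2 values shown sit. Compound 3 `COc1cccc(-c2cn(C3CC3)c3cc(N4CCNCC4)c(F)cc3c2=O)c1` carries one change from compound 1: 3-methoxyphenyl in place of 4-chlorophenyl on an aromatic carbon. Going by the values given here, the one measured step that bears on it also puts methoxy in place of chloro on an aromatic carbon, and its size is a step that the two limits leave unreadable from compound 1 to compound 2. In this assay no step beyond the scatter is therefore expected, in either direction. The estimated step is a number no higher from compound 1 to compound 3 (the limit leaves the size open). Compound 3 is expected at 400000 nM, within an estimated range of 200000 nM to 800000 nM.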

Compound 3, solubility: > 400000 nM
Compound 3: a limit, no number; the forecaster's own chance of this, stated with the estimate: 85%; the middle value lies on the limit itself.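

In this assay, compound 3 gives a limit and not a number, as do compound 1 and compound 2, so no step among these three compounds can be read. As far as these compounds go, whether their true solubilities differ, and by how much, stays open.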